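Trimming a Sulfonyl Substituent to Methyl

The compounds below may be only part of what the source reports. "The series", "measured", "known", "first", "only" and "open" are said of these compounds alone.

Compound 1 `CC(C)COc1ncc(-c2cc(F)c(-c3nnc(S(=O)(=O)CC4CC4)[nH]3)cc2F)cc1Cl`: 67 uL/min
Compound 2 `CC(C)COc1ncc(-c2cc(F)c(-c3nnc(S(=O)(=O)C4CCC4)[nH]3)cc2F)cc1Cl`: 53 uL/min

Among the compounds with values here, the series so far holds two measured compounds. In an ADME assay on microsomes from liver (Homo sapiens) for metabolic stability (on this read-out lower numbers stand for slow clearance and higher numbers for fast clearance), compound 1 gives 67 uL/min, and compound 2 gives 53 uL/min. Within the data shown here, compound 2 has the lowest number of the two, but the only measured step, a 1.3-fold lower number from compound 1 to compound 2 (0.10 log units; within the scatter), lies within the scatter, so the two compounds cannot be told apart on this read-out.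

Compound 3 `CC(C)COc1ncc(-c2cc(F)c(-c3nnc(S(C)(=O)=O)[nH]3)cc2F)cc1Cl` is not yet measured. It differs from compound 2 in one place: methyl in place of cyclobutyl on a sulfonyl sulfur. Among the measured compounds shown here, the one measured step bears on it only loosely, since it exchanged two groups of similar size on the same sulfonyl sulfur and showed a 1.3-fold lower number from compound 1 to compound 2 (0.10 log units; within the scatter). The present change is a larger cut, from a four-carbon ring to a single carbon, and nothing measured here tells how far such a cut moves the number. Compound 3 is therefore expected to come out near or somewhat under compound 2, with the estimated step of a 1.5-fold lower number from compound 2 to compound 3 (0.18 log units; within the scatter). The estimate for compound 3 is 35 uL/min, with a range from 15 uL/min to 75 uL/min.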

Compound 3, intrinsic clearance in a liver preparation (reported as CLH), per the amount of preparation that the assay uses: 41 uL/min
Compound 3: the middle estimate sits 1.2-fold (0.07 log units) below what was measured; the range from low to high includes it.
By their numbers in this assay, from the lowest: compounds 3, 2 and 1 (each within the scatter of the next).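

In this assay, the cut from cyclobutyl to methyl on the sulfonyl sulfur, which takes 4 heavy atoms down to 1 and removes the ring, gives a 1.3-fold lower number from compound 2 to compound 3 (0.11 log units; within the scatter), so this larger change in size also stays inside the usual scatter. The same holds for the pair at the two ends of the series, where hydrogen in place of cyclopropyl on a saturated chain carbon bound to a sulfonyl sulfur gives a 1.6-fold lower number from compound 1 to compound 3 (0.21 log units; within the scatter), and the three compounds, with cyclopropylmethyl, cyclobutyl and methyl at this place, cannot be told apart on this read-out. Nothing at hand accounts for this result.

The compounds shown leave open whether the number would stay in the same band with an ethyl group, a longer chain, an amine or a carboxylic acid-bearing chain on the sulfonyl sulfur. They also leave open whether a change elsewhere on the shared core, such as at the side chain carrying the ether oxygen, would move the number beyond the scatter when a change at this place has not.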